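This account rests on a few compounds, and the source may have more. Where it says the series, first, only, none or still open, it means among the compounds named here.

Working notes on the series, read in a functional assay on HOS-TE85 cells (Homo sapiens) for inhibition, read by CCK-8 assay, with a stated time of 72 h; on this read-out higher numbers stand for weaker inhibition and lower numbers for stronger inhibition. Compound 1 `O=C(NCCCCc1ccccc1)c1cccc(C2SCC(=O)N2c2cnccn2)c1` is reported as > 1000 nM, which is a limit and not a number. Compound 2 `CCN(CC)c1ccc(N2C(=O)CSC2c2cccc(C(=O)NCCCCc3ccccc3)c2)cc1` is reported as > 1000 nM, which is also only a limit. Going by the values given here, compound 3 `COc1ccc(F)cc1N1C(=O)CSC1c1cccc(C(=O)NCCCCn2cccn2)c1` gives 97.3 nM, the one true number so far. Compound 2 therefore stands at the limit of > 1000 nM in this assay, at which 2 of the 3 values shown sit, with no exact value to work from.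

Compound 4 `O=C(NCCCCc1ccccc1)c1cccc(C2SCC(=O)N2c2ccccc2)c1` has not yet been measured. Relative to compound 2 it has hydrogen in place of diethylamino on an aromatic carbon, para to a large group, so that 4-(diethylamino)phenyl becomes phenyl: hydrogen in place of diethylamino on an aromatic carbon.

Among the compounds with values here, the one measured step at this aryl group is a step that the two limits leave unreadable from compound 1 to compound 2. It swaps pyrazin-2-yl for 4-(diethylamino)phenyl on the amide-type nitrogen in the ring, and it gives no size to carry over. Within the data shown here, no measured step connects compound 3 to this change. Among the measured compounds shown here, with only that unreadable step to go on, no shift beyond the scatter is expected in this assay, in either direction. The expected result is a step that the limit leaves unreadable from compound 2 to compound 4. For compound 4 the estimate is 1500 nM, with an expected range of 400 nM to 5000 nM.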

Compound 4, half-maximal inhibitory concentration: 15.9 nM
Estimate against measurement, compound 4: 94-fold (1.97 log units) above; the measured number lies below the stated range.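

In this assay, going by these compounds alone, the aryl group on the amide-type nitrogen in the ring now proves able to move the read-out strongly, which the earlier compounds could not show, as the step between compound 1 and compound 2 cannot be read. With the rest of the structure held constant, hydrogen in place of diethylamino on an aromatic carbon, para to a large group, gives an at least 62-fold lower number from compound 2 to compound 4 (1.79 log units; beyond the scatter), and phenyl in place of pyrazin-2-yl gives an at least 62-fold lower number from compound 1 to compound 4 (1.79 log units; beyond the scatter). Among the three aryl groups carried on this side chain, unsubstituted phenyl alone gives an exact value, and both step sizes are bounds rather than measured sizes: the limit of > 1000 nM in this assay, at which 2 of the 4 values shown sit.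

The compounds shown leave open whether any group on that aromatic carbon raises the number or whether the effect is particular to diethylamino, a question that a methyl group, a fluorine atom or a dimethylamino group at the same place would help to settle. From the compounds shown here alone, compound 3 differs from compound 4 in more than one place, so the separate contributions of its aryl group and its side chain also remain open.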